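A few compounds are considered here, and "the series" means these few. Any claim that something is new, unique, unknown or untested is made for them only; others in the source may bear on it.

The shared core of this series carries a carboxylic acid and a triazole, and only the group on an aromatic nitrogen of that five-membered aromatic ring with 3 nitrogen changes. In a functional assay on PC-3 cells (Homo sapiens) for cytotoxicity, read by MTT assay, with a stated time of 24 h (a lower number here means a stronger inhibitor, a higher number a weaker inhibitor), compound 1 `COc1ccccc1-n1cc(COc2c(/C=C\C(=O)O)ccc(OC)c2CC=C(C)C)nn1` gives "not determined" (no result reported), so no number is available for it. Among the compounds with values here, compound 2 `COc1ccc(/C=C\C(=O)O)c(OCc2cn(-c3ccc(CO)cc3)nn2)c1CC=C(C)C` is the only member with a measured value: in this assay compound 2 gives 28300 nM, a weak result. Compound 3 `COc1ccc(/C=C\C(=O)O)c(OCc2cn(-c3cccnc3Cl)nn2)c1CC=C(C)C` in this assay gives "not determined" (no result reported), so compound 3 stands without a single number, and compound 1 is the other entry without one. Compound 4 `COc1ccc(/C=C\C(=O)O)c(OCc2cn(-c3cccc([N+](=O)[O-])c3)nn2)c1CC=C(C)C` differs from compound 3 by 3-nitrophenyl in place of 2-chloropyridin-3-yl on an aromatic nitrogen. Within the data shown here, with no measured step between any two compounds, no direction can be read from the data, and any shift is expected to stay within the scatter. Among the measured compounds shown here, compound 4 is expected to give about 30000 nM, within 8000 nM to 100000 nM, because compound 2 gives 28300 nM as the one measured member.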

Compound 4, half-maximal inhibitory concentration: 42100 nM
Compound 4: middle estimate off by 1.4-fold (0.15 log units), on the low side; the range from low to high includes it.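

In this assay, within the data shown here, the one step that can be read on this aromatic nitrogen is a 1.5-fold higher number from compound 2 to compound 4 (0.17 log units; within the scatter) when 3-nitrophenyl takes the place of 4-(hydroxymethyl)phenyl. These two aromatic groups differ in what they carry, yet compound 2 and compound 4 cannot be told apart in this read-out, so this change gives no direction for the position. Nothing measured here explains the result.

Steps involving compound 1 or compound 3 cannot be read, as neither has a number, so the methoxyphenyl and 2-chloropyridin-3-yl groups remain uncompared. The compounds shown also leave open whether an amine or a carboxylic acid on the aromatic group, or a longer alkyl chain in its place, would move the number beyond the usual scatter.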